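This account rests on a few compounds, and the source may have more. Where it says the series, first, only, none or still open, it means among the compounds named here.

compound 1 `C=CCn1c(=N)sc2cc(OC(F)(F)F)ccc21` gives 7 mg/kg
compound 2 `N=c1sc2cc(OC(F)(F)F)ccc2n1CCSc1ccccc1` gives 4.5 mg/kg
compound 3 `CN(C)CCCn1c(=N)sc2cc(OC(F)(F)F)ccc21` gives 9 mg/kg

These three results come from a functional assay on the whole organism with Rattus norvegicus as the target; a lower number here means that less compound is needed, a higher number that more compound is needed for the effect. Compound 3, at 9 mg/kg, lies within the usual scatter of both other compounds, so the three cannot be told apart.

The next compound is compound 4 `CC[S+]([O-])CCn1c(=N)sc2cc(OC(F)(F)F)ccc21`, which keeps the shared core but differs from compound 3 on a saturated chain carbon, two bonds along the chain from an aromatic nitrogen: a group of 4 heavy atoms (2 carbon, 1 oxygen, 1 sulfur; no ring) in place of a group of 4 heavy atoms (3 carbon, 1 nitrogen; no ring), on a saturated chain carbon, two bonds along the chain from an aromatic nitrogen.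

The most relevant comparison is a swap at this same place, a 2.0-fold higher number from compound 2 to compound 3 (0.30 log units; within the scatter). The two remaining steps, a 1.6-fold lower number from compound 1 to compound 2 (0.19 log units; within the scatter) and a 1.3-fold higher number from compound 1 to compound 3 (0.11 log units; within the scatter), alter the chain in other ways. All three steps stay within the scatter, so these compounds give no sign of a large effect from changing the chain. Among the compounds with values here, no measured compound carries the entering group, however, which leaves real uncertainty.

No change beyond the scatter is expected, and the estimated step is a 1.3-fold lower number from compound 3 to compound 4 (0.11 log units; within the scatter). For compound 4 the expected value is 7 mg/kg, with an estimated range from 3 mg/kg to 16 mg/kg.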

Compound 4, dose for half-maximal effect: 1.2 mg/kg
Compound 4: middle estimate off by 5.8-fold (0.77 log units), on the high side; the measured number lies below the stated range.
By their numbers in this assay, from the lowest: compound 4; then compounds 2, 1 and 3 (each within the scatter of the next).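

In this assay this chain position proves able to shift the number: the earlier swaps all stayed within the scatter, but replacing (dimethylamino)methyl with the group holding sulfur and oxygen brings a 7.5-fold lower number from compound 3 to compound 4 (0.88 log units; beyond the scatter) in a single change. The result does not depend on one reference point, as the comparisons with the other two compounds also lie beyond the scatter, with a 3.8-fold lower number from compound 2 to compound 4 (0.57 log units; beyond the scatter) against the phenylsulfanyl chain and a 5.8-fold lower number from compound 1 to compound 4 (0.77 log units; beyond the scatter) against the allyl-type chain. No measured information explains this difference.

The compounds shown leave open whether the oxygen on sulfur matters, as no ethylsulfanyl group without that oxygen stands among them. Also open, going by these compounds, is whether a sulfone, with a second oxygen on the sulfur, or a longer chain would lower the number further.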